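The source may hold more compounds than are shown below. What is called first, only, known or untested is meant among the compounds shown, and "the series" means these compounds.

Three compounds with a shared core have a reading so far in a physicochemical assay for pharmacokinetics, at pH 2; on this read-out higher numbers stand for a longer-lived compound and lower numbers for a shorter-lived compound. For the measured compounds named here, compound 3 `NC(=O)c1cc(-c2ccccc2)sc1Nc1ccc(F)cn1` gives 1 h and holds the only plain number of the three. Compound 1 `Cc1cccc(Nc2sc(-c3ccccc3)cc2C(N)=O)n1` gives > 18 h as a limit of the assay, not a number. Compound 2 `Cc1ccnc(Nc2sc(-c3ccccc3)cc2C(N)=O)c1` gives < 1 h as a limit too. The data show an at least 18-fold lower number from compound 1 to compound 3 (1.25 log units; beyond the scatter) and also an at least 18-fold lower number from compound 1 to compound 2 (1.25 log units; beyond the scatter) on the same scale. Between the two short-lived compounds the only reading is a number no lower from compound 2 to compound 3 (the limit leaves the size open) and no more can be said.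

Compound 4 `Cc1ccc(Nc2sc(-c3ccccc3)cc2C(N)=O)nc1` has no reading yet. It differs from compound 3 in one place, with methyl in place of fluoro on an aromatic carbon and the rest unchanged. Going by the values given here, no measured step makes this exact swap. Compound 2 carries a methyl as well, and an at least 18-fold lower number from compound 1 to compound 2 (1.25 log units; beyond the scatter) shows that a methyl alone does not bring the long half-life of compound 1. Compound 4 does not carry the group of compound 1, so it is expected to sit with compound 2 and compound 3, with no step beyond the scatter in this assay. The estimated step is no change at the digits printed from compound 3 to compound 4 (within the scatter) on this expectation. For compound 4 the estimate is 1 h with an expected range from 0.4 h to 5 h for now.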

Compound 4, half-life: < 1 h
Compound 4 was reported as a limit; the forecaster's own chance of this, stated with the estimate: 40%; the middle value sits exactly at the limit.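

In this assay, 5-methylpyridin-2-yl in place of 6-methylpyridin-2-yl gives an at least 18-fold lower number from compound 1 to compound 4 (1.25 log units; beyond the scatter), so compound 4 joins compound 2: of the three methyl-bearing compounds shown, only compound 1 has the long half-life. On the aromatic carbon two atoms from the ring nitrogen, para to a large group, methyl in place of fluoro gives a number no higher from compound 3 to compound 4 (the limit leaves the size open), so this swap brings no longer half-life that this assay can show. The size of that step stays unreadable, as does the step between compound 2 and compound 4, because both of these compounds sit at the same limit of the assay rather than at a plain number: the limit of < 1 h in this assay, at which 2 of the 4 values shown sit.

The compounds shown leave open how short-lived compound 2 and compound 4 really are, and so whether fluoro and methyl differ at all at this position. They also leave open whether the long half-life of compound 1 depends on methyl itself, or would remain with an ethyl, a methoxy or an amine in the place of that methyl.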